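Benzisoselenazolone thiadiazole series: chloro to methyl at the ortho position

This account rests on a few compounds, and the source may have more. Where it says the series, first, only, none or still open, it means among the compounds named here.

Measured so far:
compound 1 `O=c1c2ccccc2[se]n1-c1nnc(-c2ccc(Br)cc2)s1` — 39100 nM
compound 2 `O=c1c2ccccc2[se]n1-c1nnc(-c2ccc(Cl)cc2)s1` — 10400 nM
compound 3 `O=c1c2ccccc2[se]n1-c1nnc(-c2ccccc2Cl)s1` — 10100 nM

In a functional assay on A549 cells (Homo sapiens) for antiproliferative activity, read by CCK-8 assay, with a stated time of 48 h (on this read-out lower numbers stand for stronger inhibition and higher numbers for weaker inhibition), compound 3 gives 10100 nM, the lowest of the three numbers, though compound 2 stands within the scatter of it; only compound 1 is clearly separated, with a 3.9-fold lower number from compound 1 to compound 3 (0.59 log units; beyond the scatter).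

Compound 4 `Cc1ccccc1-c1nnc(-n2[se]c3ccccc3c2=O)s1` differs from compound 3 by methyl in place of chloro on an aromatic carbon. Among the measured compounds shown here, no measured step exchanges a halogen for a carbon substituent, so the change is not covered directly. The steps that come nearest are a 3.8-fold lower number from compound 1 to compound 2 (0.58 log units; beyond the scatter), a swap of one halogen for another, and a 1.0-fold lower number from compound 2 to compound 3 (0.01 log units; within the scatter), a move of the same halogen to the other position. Both indicate that small changes on this phenyl ring shift this assay by modest amounts at most, and the repositioning of chloro by nothing beyond the scatter.

On that basis the step from compound 3 to compound 4 is expected to be small, a 1.3-fold higher number from compound 3 to compound 4 (0.11 log units; within the scatter), with no direction that the data can support. Compound 4 is therefore estimated at 13000 nM in this assay, within a range of 4000 nM to 45000 nM; the range is broad, since no listed step involves a methyl group.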

Compound 4, half-maximal inhibitory concentration: 18600 nM
Compound 4: middle estimate off by 1.4-fold (0.16 log units), on the low side; measured number inside the range.
By their numbers in this assay, from the lowest: compounds 3, 2 and 4 (each within the scatter of the next); then compound 1.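

In this assay, among the compounds shown here, methyl in place of chloro on this aromatic carbon, ortho to a large group, gives a 1.8-fold higher number from compound 3 to compound 4 (0.27 log units; within the scatter) and so stays within the scatter; this is the first exchange of a halogen for a carbon substituent, and here it does not separate the two compounds. For the compounds shown here, compound 4 is also not separated from the chloro compound with the other substitution pattern, with a 1.8-fold higher number from compound 2 to compound 4 (0.25 log units; within the scatter) across that pair, whereas a 2.1-fold lower number from compound 1 to compound 4 (0.32 log units; beyond the scatter) places compound 1 beyond the scatter, so compound 1 remains the only compound clearly apart from the other three. No data are available that account for these results at this position.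

The compounds shown carry only chloro, bromo or methyl on the phenyl ring, so it remains open whether a methoxy group, an amine, a carboxylic acid or a longer chain on this carbon would stay within the same narrow band. Going by these compounds alone, whether methyl elsewhere on the phenyl ring would behave as it does here is also open, since compound 4 is the only methyl compound in the set.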